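A Fluoro Analogue Weighed Against Three Trifluoromethyl Enones

The source may report more compounds than this note shows. Statements on the series, on what has been measured and on what is new or still open speak of the compounds shown alone.

Three enones sharing a cyclohexene-derived core were tested in a functional assay on PC-3 cells (Homo sapiens) for cytotoxicity, read by MTT assay, with a stated time of 72 h; a lower number here means a stronger inhibitor, a higher number a weaker inhibitor. Compound 1 `CC1=CCCC(C)(C)C1/C=C/C(=O)/C=C/c1ccc(C(F)(F)F)cc1` gives 7900 nM. Compound 2 `CC1=C(/C=C/C(=O)/C=C/c2ccc(C(F)(F)F)cc2)C(C)(C)CCC1O` gives 10200 nM, and compound 3 `CC1=C(/C=C/C(=O)/C=C/c2cc(C(F)(F)F)cc(C(F)(F)F)c2)C(C)(C)CCC1O` gives 7000 nM. For the measured compounds named here, all three numbers lie close together: the gaps from compound 2 to compound 1 and to compound 3 both fall within the usual scatter of this assay, so no member of the trio can be set apart as stronger or weaker.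

Compound 4 `CC1=C(/C=C/C(=O)/C=C/c2ccc(F)cc2)C(C)(C)CCC1O` is not yet measured. It differs from compound 2 by a single change, (fluoro in place of trifluoromethyl on an aromatic carbon), that is, fluoro in place of trifluoromethyl on an aromatic carbon. Going by the values given here, no measured pair in this set isolates that change, so the direction of the step is unknown. Given how little the three measured compounds move among themselves, the expected step is a 1.2-fold higher number from compound 2 to compound 4 (0.07 log units; within the scatter), and none beyond the scatter is anticipated. Compound 4 is therefore estimated at 12000 nM, with a range from 5000 nM to 30000 nM in this assay.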

Compound 4, half-maximal inhibitory concentration: 6200 nM
Beside the measured number, compound 4's estimate is 1.9-fold (0.29 log units) above it; the measured number falls inside the stated range.
By their numbers in this assay, from the lowest: compounds 4, 3, 1 and 2 (each within the scatter of the next).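

In this assay, for the compounds shown here, the swap of trifluoromethyl for fluoro on an aromatic carbon, para to a large group, gives a 1.6-fold lower number from compound 2 to compound 4 (0.22 log units; within the scatter) and is the first single-place step in this set. The change removes 4 heavy atoms and brings in 1, yet the step stays within the scatter, so this read-out does not separate the two groups at this position. Nothing measured here speaks to the reason for that.

From the compounds shown here alone, whether an amine, a carboxylic acid or a methoxy group on the same aromatic carbon would give a step beyond the scatter remains open. Going by these compounds, it is also open whether the swap of trifluoromethyl for fluoro would read the same on the core of compound 1.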